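This account rests on a few compounds, and the source may have more. Where it says the series, first, only, none or still open, it means among the compounds named here.

Compound 1, `CCC1(c2cccc(Cl)c2)ON=C(c2ccccc2Cl)O1`: in an ADME assay on HEK293 cells (Homo sapiens) for cytotoxicity, read by MTT assay, with a stated time of 44 h (a higher number here means a weaker inhibitor, a lower number a stronger inhibitor), compound 1 gives only the limit > 100000 nM.
Compound 2, `CCC1(c2cccc(Br)c2)ON=C(c2cccc(Cl)c2)O1`: in this assay compound 2 gives only the limit > 100000 nM.
Compound 3, `CCC1(c2cccc(Cl)c2)ON=C(c2ccc(Cl)cc2)O1`: in this assay compound 3 gives only the limit > 100000 nM.

Compound 3 therefore stands at the limit, where all three values sit (the limit of > 100000 nM in this assay, at which 3 of the 3 values shown sit). Within the data shown here, the one step between measured compounds, a step that the two limits leave unreadable from compound 1 to compound 3, is left unreadable by the two limits.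

Compound 4, `CCC1(c2cccc(Br)c2)ON=C(c2ccc(Cl)cc2)O1`, differs from compound 3 by bromo in place of chloro on an aromatic carbon. Among the measured compounds shown here, no measured step covers this change. Compound 2 already carries a bromo group on the same ring and also gives only a limit in this assay. For compound 4 no step beyond the scatter is expected, a step that the limit leaves unreadable from compound 3 to compound 4. The estimate for compound 4 is 150000 nM, with a range from 60000 nM to 400000 nM, most likely again reported as a limit.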

Compound 4, half-maximal inhibitory concentration: > 100000 nM
Compound 4 ended at the assay's limit (the forecaster's own chance of this, stated with the estimate: 85%); the middle value is on the limit's open side.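

Compound 4, like compound 2 and compound 3, gives only a limit, so no new step can be read between compound 4 and either of them: the limit of > 100000 nM in this assay, at which 4 of the 4 values shown sit.
The compounds shown leave open whether any change to this series gives a true number in this assay rather than a limit.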